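Aryl exchange on the saturated ring carbon, compound 4

The source may report more compounds than this note shows. Statements on the series, on what has been measured and on what is new or still open speak of the compounds shown alone.

Measured so far:
compound 1, `Cc1ccc(C(=O)C2=C(O)C(=O)N(CC(C)O)C2c2ccc(C(C)C)cc2)cc1`, 101%
compound 2, `CCCc1ccc(C2C(C(=O)c3ccc(C)cc3)=C(O)C(=O)N2CC(C)O)cc1`, 97%
compound 3, `Cc1ccc(C(=O)C2=C(O)C(=O)N(CC(C)O)C2c2cccc(C(F)(F)F)c2)cc1`, 110%

In an assay on isolated protein for inhibition of annexin A2/S100-A10 (Homo sapiens), with a stated time of 5 min, tested at 50 uM (on this read-out lower numbers stand for less inhibition and higher numbers for more inhibition at the one concentration tested (going by the name of the read-out)), compound 3 gives the highest of the three numbers; compound 1 lies within the scatter of it, compound 2 beyond it. Compound 4, `Cc1ccc(C(=O)C2=C(O)C(=O)N(CC(C)O)C2c2cc(Cl)cc(Cl)c2)cc1`, is unmeasured and differs from compound 3 by 3,5-dichlorophenyl in place of 3-(trifluoromethyl)phenyl on a saturated ring carbon. Two measured steps exchange the aryl group on the same saturated ring carbon: a number 9 percentage points higher from compound 1 to compound 3 (within the scatter) and a number 13 percentage points higher from compound 2 to compound 3 (beyond the scatter). Both are small, and all three measured numbers lie close to one another at the single concentration, so the expected step is a number 8 percentage points lower from compound 3 to compound 4 (within the scatter), within the scatter. Compound 4 is expected to give 102% in this assay, between 85% and 115%.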

Compound 4, a percentage reported as inhibition, at one concentration (the size of the read-out at that concentration, not a potency): 119%
Beside the measured number, compound 4's estimate is 17 percentage points below it; measured number above the stated range.
By their numbers in this assay, from the lowest: compounds 2, 1, 3 and 4 (each within the scatter of the next, the first and the last beyond it).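

In this assay, 3,5-dichlorophenyl on the saturated ring carbon stands level with 3-(trifluoromethyl)phenyl, a number 9 percentage points higher from compound 3 to compound 4 (within the scatter). Against the alkyl-bearing aryl groups, the exchange gives a number 22 percentage points higher from compound 2 to compound 4 (beyond the scatter) and a number 18 percentage points higher from compound 1 to compound 4 (beyond the scatter), so compound 4 is separated from both, whereas compound 3 is separated only from compound 2. Nothing measured here bears on the reason for this separation.

The compounds shown leave open whether a carboxylic acid or an amine on this aryl ring would keep the number at this level.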